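A few compounds are considered here, and "the series" means these few. Any claim that something is new, unique, unknown or untested is made for them only; others in the source may bear on it.

Three measured compounds share one core and differ only in the groups on their two outer aromatic rings. Compound 2 `COc1ccc(C2=NN(C(=O)c3ccc4c(c3)OCCO4)C(c3ccccc3)C2)cc1` carries a plain phenyl on one side. In a functional assay on WM 266-4 cells (Homo sapiens) for inhibition, read by MTT assay, with a stated time of 24 h (on this read-out higher numbers stand for weaker inhibition of growth and lower numbers for stronger inhibition of growth), compound 2 gives 2370 nM, the second highest of the three numbers. Compound 1 `COc1ccc(C2=NN(C(=O)c3ccc4c(c3)OCCO4)C(c3ccc(F)cc3)C2)cc1` gives 3780 nM in this assay, and compound 3 `O=C(c1ccc2c(c1)OCCO2)N1N=C(c2ccc(Br)cc2)CC1c1ccccc1` gives 1790 nM. The step of a 1.6-fold lower number from compound 1 to compound 2 (0.20 log units; within the scatter) lies within the scatter, as does the step of a 1.3-fold lower number from compound 2 to compound 3 (0.12 log units; within the scatter), so none of the three can be ranked against the others.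

Compound 4 `COc1ccc(C2=NN(C(=O)c3ccc4c(c3)OCCO4)C(c3ccc(OC)cc3)C2)cc1` is not yet measured. It differs from compound 2 by methoxy in place of hydrogen on an aromatic carbon. The step from compound 1 to compound 2 bears most directly on this change, since it swaps a group on the same aromatic carbon, and it stayed within the scatter; the step from compound 2 to compound 3, which exchanges groups on the other ring, also stayed within the scatter. With no change beyond the scatter anywhere among these compounds, the expected step in this assay is none beyond the scatter, and a 1.0-fold higher number from compound 2 to compound 4 (0.01 log units; within the scatter) is the estimated outcome. Compound 4 is therefore expected to give about 2400 nM, with a likely range from 1000 nM to 5800 nM.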

Compound 4, concentration for 50% growth inhibition: 9890 nM
For compound 4 the middle estimate is 4.1-fold (0.61 log units) below the measured one; the measured number lies above the stated range.
By their numbers in this assay, from the lowest: compounds 3, 2 and 1 (each within the scatter of the next, the first and the last beyond it); then compound 4.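

In this assay this aromatic carbon, para to a large group, turns out not to be indifferent to what it carries: hydrogen and fluoro could not be told apart here, yet methoxy in place of hydrogen gives a 4.2-fold higher number from compound 2 to compound 4 (0.62 log units; beyond the scatter) and so passes beyond the scatter. Methoxy in place of fluoro on the same carbon gives a 2.6-fold higher number from compound 1 to compound 4 (0.42 log units; beyond the scatter) and also passes beyond the scatter, so both steps point the same way, and on this read-out a higher number means weaker inhibition of growth. Nothing given here explains why the methoxy compound stands apart from the other two.

Going by these compounds, only hydrogen, fluoro and methoxy can be compared on this carbon, so it remains open whether a hydroxyl, an amine or a longer ether such as ethoxy would give a similar step, or whether the step is particular to methoxy. On these data alone, it also remains open whether the same step would appear with bromo rather than methoxy on the other ring, as in compound 3, since the step has been read only with methoxy there.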